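The source may report more compounds than this note shows. Statements on the series, on what has been measured and on what is new or still open speak of the compounds shown alone.

Measured in an ADME assay on MCF7 cells (Homo sapiens) for cytotoxicity, read by MTT assay, with a stated time of 11 days; on this read-out higher numbers stand for weaker inhibition of growth and lower numbers for stronger inhibition of growth:

Compound 1 `CCCCCc1cc2c(=O)n(CCC)cnc2s1`: 33.8 ug/mL
Compound 2 `CCCCCCCc1cc2c(=O)n(CC#N)cnc2s1`: > 100 ug/mL

Compound 2 has no exact number in this assay. Its reading of > 100 ug/mL is a limit of the assay. Compound 1, by contrast, gives a full number, 33.8 ug/mL. For the measured compounds named here, the two measured compounds do not form a single-change pair, so no measured step is available as a guide.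

The next compound is compound 3 `CCCCCCCc1cc2c(=O)n(CCN=[N+]=[N-])cnc2s1`, which departs from compound 2 in one place: azidomethyl in place of cyano on a saturated chain carbon bound to an aromatic nitrogen. Azidomethyl stands in place of cyano on a saturated chain carbon bound to an aromatic nitrogen. Cut one bond further out, the same difference reads cyanomethyl to 2-azidoethyl.

Going by the values given here, the only anchor for a number is compound 1 at 33.8 ug/mL, so the expectation is loose. A move toward stronger inhibition of growth is expected in this assay, with an estimated size of an at least 1.8-fold lower number from compound 2 to compound 3 (0.25 log units; that floor lies within the scatter). A reading that again gives only a limit remains quite possible. For compound 3 the estimated value is 55 ug/mL, with an expected range of 20 ug/mL to 100 ug/mL.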

Compound 3, concentration for 50% growth inhibition: > 100 ug/mL
Compound 3: only a limit was reported; the forecaster's own chance of this, stated with the estimate: 35%; middle value at least 1.8-fold (0.25 log units) from the limit.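

In this assay compound 3 gives > 100 ug/mL as a limit of the assay and not a number. Compound 2 also stands at a limit, so no step between compound 2 and compound 3 can be read: the limit of > 100 ug/mL in this assay, at which 2 of the 3 values shown sit.

The compounds shown leave open whether azidomethyl in place of cyano changes the inhibition of growth at all.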